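Compound 2 to compound 4: methoxy to phenoxy

The source may report more compounds than this note shows. Statements on the series, on what has been measured and on what is new or still open speak of the compounds shown alone.

In a functional assay on DU-145 cells (Homo sapiens) for inhibition, read by sulforhodamine B assay, with a stated time of 48 h (on this read-out higher numbers stand for weaker inhibition of growth and lower numbers for stronger inhibition of growth), compound 2 (`COc1cccc(C(=O)NNC(=O)c2ccc3[nH]c(-c4ccc([N+](=O)[O-])o4)nc3c2)c1`) gives 15.6 ug/mL, level with compound 1 (`O=C(NNC(=O)c1ccc2[nH]c(-c3ccc([N+](=O)[O-])o3)nc2c1)c1ccccc1`) at 15.6 ug/mL and compound 3 (`O=CNNC(=O)c1ccc2[nH]c(-c3ccc([N+](=O)[O-])o3)nc2c1`) at 15.6 ug/mL. Compound 4 (`O=C(NNC(=O)c1ccc2[nH]c(-c3ccc([N+](=O)[O-])o3)nc2c1)c1cccc(Oc2ccccc2)c1`) has phenyl in place of methyl on an oxygen on an aromatic ring, which turns methoxy into phenoxy: phenyl in place of methyl on an oxygen on an aromatic ring.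

For the measured compounds named here, three measured steps bear on this change. Methoxy in place of hydrogen on an aromatic carbon gave no change at the digits printed from compound 1 to compound 2 (within the scatter). Hydrogen in place of phenyl on a carbonyl carbon gave no change at the digits printed from compound 1 to compound 3 (within the scatter). Hydrogen in place of 3-methoxyphenyl on a carbonyl carbon gave no change at the digits printed from compound 2 to compound 3 (within the scatter). None of the three shows a size or direction to carry forward. Going by the values given here, no measured compound carries phenoxy, so the expectation is an extrapolation from these level values.

In this assay no shift beyond the scatter is expected, and the estimated step is no change at the digits printed from compound 2 to compound 4 (within the scatter). For compound 4 the expected value is 15.6 ug/mL, with an estimated range of 7.8 ug/mL to 31.2 ug/mL.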

Compound 4, concentration for 50% growth inhibition: > 7.8 ug/mL
Compound 4: only a limit was reported; the forecaster's own chance of this, stated with the estimate: 5%; the middle value is on the limit's open side.
By their numbers in this assay, from the lowest: compounds 1, 2 and 3 (each within the scatter of the next).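

In this assay compound 4 is reported only as the limit > 7.8 ug/mL and its steps from compound 1 and from compound 2 cannot be read. From the compounds shown here alone, whether phenoxy in place of methoxy shifts growth inhibition at all, and in which direction, stays open.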